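The source may hold more compounds than are shown below. What is called first, only, known or untested is meant among the compounds shown, and "the series" means these compounds.

Series notes. Compound 1 `Cc1ccc(-c2csc(=N)n2CC(=O)N2CCN(c3ccccc3)CC2)cc1` and compound 2 `Cc1ccc(-c2csc(=N)n2CC(=O)N2CCOCC2)cc1` both carry a 4-methylphenyl group; the difference between the two cores is not broken down here. In an assay on isolated protein for inhibition of leukotriene A-4 hydrolase (Homo sapiens) (on this read-out lower numbers stand for stronger inhibition and higher numbers for weaker inhibition), compound 1 gives 4290 nM, and compound 2 gives 3560 nM; the two numbers lie within the scatter of each other, so no order is drawn between them. Compound 3 `N=c1scc(-c2ccc(Cl)cc2)n1CC(=O)N1CCN(c2ccccc2)CC1` has the core of compound 1 with one change, (chloro in place of methyl on an aromatic carbon). In this assay compound 3 gives 93 nM, and the step is a 46-fold lower number from compound 1 to compound 3 (1.66 log units; beyond the scatter).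

Compound 4 `N=c1scc(-c2ccc(Cl)cc2)n1CC(=O)N1CCOCC1` has not yet been measured. It stands to compound 2 as compound 3 stands to compound 1: the change is chloro in place of methyl on an aromatic carbon, the same change at the same place, read one bond further out as 4-methylphenyl to 4-chlorophenyl. Among the compounds with values here, only one measured instance of this change exists, from compound 1 to compound 3, and the core around it differs from that of compound 2 in a way that is not broken down here, so the transfer carries some uncertainty. The step from compound 2 to compound 4 is expected to be about a 36-fold lower number from compound 2 to compound 4 (1.55 log units; beyond the scatter), because the same change gave a 46-fold lower number from compound 1 to compound 3 (1.66 log units; beyond the scatter) and compound 2 starts from 3560 nM. On that basis compound 4 is expected to give about 100 nM in this assay, with a plausible range from 30 nM to 400 nM; the measurement will show whether the step carries over.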

Compound 4, inhibition constant: 1060 nM
Beside the measured number, compound 4's estimate is 11-fold (1.03 log units) below it; the whole stated range lies below it.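

In this assay, chloro in place of methyl on an aromatic carbon again gives a lower number on the core of compound 2, with a 3.4-fold lower number from compound 2 to compound 4 (0.53 log units; beyond the scatter), so the direction of the change holds on both cores shown. The size of the change does not carry over, and the gain seen on the core of compound 1 is therefore not a fixed increment that can simply be added to another core in this series: the same change on two cores in this assay, a 46-fold lower number (1.66 log units; beyond the scatter) from compound 1 to compound 3 and a 3.4-fold lower number (0.53 log units; beyond the scatter) from compound 2 to compound 4, 14-fold (1.14 log units) apart, beyond the scatter of two such steps These two pairs show that the core affects how much this change achieves, but they do not show which part of the core is responsible or how large the step would be on a third core, and two cores are too few to support a rule.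

The compounds shown leave open whether the dependence on the core is specific to chloro or would also appear with another group at the same place, such as bromo, methoxy or trifluoromethyl. They also leave open how the step would behave if the group on the amide nitrogen were replaced by something else, such as a simple open-chain amine or a longer chain bearing a carboxylic acid.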